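Removing the amide methyl in a fused spiro series

The source may hold more compounds than are shown below. What is called first, only, known or untested is meant among the compounds shown, and "the series" means these compounds.

Compound 1, `Cc1ccc([C@@H]2CN(C)[C@]3(C(=O)Nc4ccccc43)[C@]23Cc2ccccc2C3=O)cc1`: 17.1%
Compound 2, `COc1ccc([C@@H]2CN(C)[C@]3(C(=O)N(C)c4ccccc43)[C@]23Cc2ccccc2C3=O)cc1`: 3.8%

Of these two numbers, compound 2 stands lowest, and compound 1 lies above it by more than the usual scatter. Compound 3 `COc1ccc([C@@H]2CN(C)[C@]3(C(=O)Nc4ccccc43)[C@]23Cc2ccccc2C3=O)cc1` has not yet been measured. It differs from compound 2 in one respect: hydrogen in place of methyl on an amide-type nitrogen in a ring. Among the measured compounds shown here, no single-change step has been measured in a functional assay on the whole organism (strain Wister albino) for inhibition, with Rattus norvegicus as the target, read by paw edema, with stated times of 1 h and 4 h, at a dose of 50 mg/kg by the intraperitoneal route (on this read-out lower numbers stand for less inhibition and higher numbers for more inhibition at the one dose given (going by the name of the read-out)), so the size of this change is uncertain; a moderate rise in this assay is expected, since compound 1 gave 17.1% while carrying hydrogen on the same nitrogen. Compound 3 is expected to give 12%, within 2% to 24%. This expectation corresponds to a step of a number 8.2 percentage points higher from compound 2 to compound 3 (within the scatter).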

Compound 3, a percentage reported as inhibition, in the whole organism at one dose (the size of the read-out at that dose, not a potency): 21.8%
Estimate against measurement, compound 3: 9.8 percentage points below; the range from low to high includes it.
By their numbers in this assay, from the lowest: compound 2; then compounds 1 and 3 (each within the scatter of the next).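

In this assay, among the compounds shown here, hydrogen in place of methyl on the amide-type nitrogen gives a number 18 percentage points higher from compound 2 to compound 3 (beyond the scatter), the first single-change step at this position, and it lies beyond the scatter. Methoxy in place of methyl on an aromatic carbon gives a number 4.7 percentage points higher from compound 1 to compound 3 (within the scatter), which is within the scatter, so this assay does not separate those two groups. Nothing on hand accounts for the effect of the change on the nitrogen.

As far as these compounds go, whether an ethyl group on that nitrogen would behave like methyl or like hydrogen remains open. So does the effect of a chlorine atom or a hydroxyl group on the aromatic carbon.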